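Vinyl in place of ethynyl on an aryl amide

The source may report more compounds than this note shows. Statements on the series, on what has been measured and on what is new or still open speak of the compounds shown alone.

Measured compounds in a functional assay on MGC-803 cells (Homo sapiens) for inhibition, read by MTT assay, with a stated time of 48 h; on this read-out higher numbers stand for weaker inhibition and lower numbers for stronger inhibition:
compound 1 `C/C=C/C(=O)N(Cc1cc(OC)c(OC)c(OC)c1)c1ccc(OC)c(O)c1` gives 6150 nM
compound 2 `C#CC(=O)N(Cc1ccc(OC)c(O)c1)c1cc(OC)c(OC)c(OC)c1` gives 170 nM

Going by the values given here, compound 2 stands at the lower of the two numbers; the number for compound 1 lies beyond the scatter above it, though the two structures differ in more than one place, so no single step connects them. Compound 3 `C=CC(=O)N(Cc1ccc(OC)c(O)c1)c1cc(OC)c(OC)c(OC)c1` differs from compound 2 by vinyl in place of ethynyl on a carbonyl carbon. Among the compounds with values here, with no measured step of this kind to lean on, only a small step toward weaker inhibition, close to the scatter, is expected, a 1.6-fold higher number from compound 2 to compound 3 (0.22 log units; within the scatter). In this assay compound 3 is therefore expected to give about 280 nM, with a likely range from 90 nM to 900 nM.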

Compound 3, half-maximal inhibitory concentration: 62 nM
Estimate against measurement, compound 3: 4.5-fold (0.65 log units) above, and the stated range ends above it.
By their numbers in this assay, from the lowest: compound 3; then compound 2; then compound 1.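

In this assay the group on the carbonyl carbon proves able to shift the number beyond the scatter: vinyl in place of ethynyl gives a 2.7-fold lower number from compound 2 to compound 3 (0.44 log units; beyond the scatter) even though both groups count the same heavy atoms and differ only in a double versus a triple bond. Compound 1 could not show this, since it differs from the others in more than one place. Nothing available explains this step.

The compounds shown leave open how an ethyl group on the same carbonyl carbon would compare with vinyl. They also leave open whether the step holds on a different core.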